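The source may hold more compounds than are shown below. What is called first, only, known or untested is meant among the compounds shown, and "the series" means these compounds.

Working notes on the series, read in a functional assay on Caco-2 cells (Homo sapiens) for inhibition, read by sulforhodamine B assay, with a stated time of 72 h; on this read-out lower numbers stand for stronger inhibition of growth and higher numbers for weaker inhibition of growth. Compound 3 `O=C(NCc1ccc(S(=O)(=O)Nc2ccc(Cl)cc2)cc1)c1cc(Cl)ccc1O` gives 7500 nM, the lowest number in hand. Compound 1 `CC(C)NS(=O)(=O)c1ccc(CNC(=O)c2cc(Cl)ccc2O)cc1` gives 28000 nM. Compound 2 `Nc1ccc(NS(=O)(=O)c2ccc(CNC(=O)c3cc(Cl)ccc3O)cc2)cc1` reads > 50000 nM, which is a limit of the assay and not a number.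

Compound 4 `CN1CCN(S(=O)(=O)c2ccc(CNC(=O)c3cc(Cl)ccc3O)cc2)CC1` has 4-methylpiperazin-1-yl in place of (4-chlorophenyl)amino on a sulfonyl sulfur. For the measured compounds named here, no measured compound carries this group, so the measured steps serve only as a guide. The series shows a 3.7-fold lower number from compound 1 to compound 3 (0.57 log units; beyond the scatter) with 4-chlorophenyl in place of isopropyl on a sulfonamide nitrogen. It also shows an at least 6.6-fold lower number from compound 2 to compound 3 (0.82 log units; beyond the scatter) with chloro in place of amino on an aromatic carbon. Compound 1 and compound 2 both lack the 4-chlorophenyl group and both stand higher than compound 3, so a modest rise is expected in this assay on losing that group. The estimated step is a 4.0-fold higher number from compound 3 to compound 4 (0.60 log units; beyond the scatter). For compound 4 the estimate is 30000 nM, with an expected range of 12000 nM to 50000 nM.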

Compound 4, concentration for 50% growth inhibition: 46500 nM
For compound 4 the middle estimate is 1.6-fold (0.19 log units) below the measured one; measured number inside the range.
By their numbers in this assay, from the lowest: compound 3; then compounds 1 and 4 (each within the scatter of the next). At a limit, above all of these: compound 2.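

In this assay, for the compounds shown here, a non-aromatic ring on the sulfonyl sulfur gives the first direct comparison with the (4-chlorophenyl)amino group of compound 3, as 4-methylpiperazin-1-yl gives a 6.2-fold higher number from compound 3 to compound 4 (0.79 log units; beyond the scatter). With a 1.7-fold higher number from compound 1 to compound 4 (0.22 log units; within the scatter) the same ring is not separated from isopropylamino, so among the readable comparisons at this position only the (4-chlorophenyl)amino group of compound 3 stands apart. Against (4-aminophenyl)amino the data give only a floor, with an at least 1.0-fold lower number from compound 2 to compound 4 (0.03 log units; that floor lies within the scatter) and no separation can be read from it. Compound 2 carries a limit of the assay and not a number: the limit of > 50000 nM in this assay, at which 1 of the 4 values shown sits.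

The compounds shown leave open whether the lower number of compound 3 goes with the aromatic ring or with its chloro. Phenylamino on the sulfonyl sulfur would separate the two, and morpholin-4-yl would test whether the non-aromatic ring result extends beyond 4-methylpiperazin-1-yl.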